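Carbonyl substituent change from compound 3 to compound 4

The compounds below may be only part of what the source reports. "The series", "measured", "known", "first", "only" and "open" are said of these compounds alone.

Measured in an ADME assay on MT4 cells (Homo sapiens) for cytotoxicity, read by MTT assay; a higher number here means that more compound is tolerated, a lower number that less compound is tolerated:
- compound 1 `Cc1ccccc1C(=O)N(C(=S)OCCN1C(=O)c2ccccc2C1=O)c1ccc(Cl)cc1`: 21000 nM
- compound 2 `Cc1cccc(C(=O)N(C(=S)OCCN2C(=O)c3ccccc3C2=O)c2ccc(Cl)cc2)c1`: 58000 nM
- compound 3 `Cc1cc(C(=O)N(C(=S)OCCN2C(=O)c3ccccc3C2=O)c2ccc(Cl)cc2)c(C)o1`: 40000 nM

Compound 3, at 40000 nM, lies within the scatter of both other compounds: a 1.5-fold lower number from compound 2 to compound 3 (0.16 log units; within the scatter) and a 1.9-fold higher number from compound 1 to compound 3 (0.28 log units; within the scatter).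

Compound 4 `O=C1c2ccccc2C(=O)N1CCOC(=S)N(C(=O)c1cccc2ccccc12)c1ccc(Cl)cc1` differs from compound 3 by a single change: naphthalen-1-yl in place of 2,5-dimethylfuran-3-yl on a carbonyl carbon. This puts naphthalen-1-yl in place of 2,5-dimethylfuran-3-yl on a carbonyl carbon.

The three measured steps all concern this same place. Only one goes beyond the scatter, and it is modest: a 2.8-fold higher number from compound 1 to compound 2 (0.44 log units; beyond the scatter). None of them brings in naphthalen-1-yl, so the data give no direct reading of this group. A step beyond the scatter in this assay is therefore not expected. The expected step is a 1.2-fold lower number from compound 3 to compound 4 (0.08 log units; within the scatter). Compound 4 is estimated at 33000 nM, with an expected range of 14000 nM to 75000 nM.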

Compound 4, half-maximal cytotoxic concentration: 6000 nM
Compound 4: the middle estimate sits 5.5-fold (0.74 log units) above what was measured; the whole stated range lies above it.
By their numbers in this assay, from the lowest: compound 4; then compounds 1, 3 and 2 (each within the scatter of the next, the first and the last beyond it).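

In this assay, this carbonyl carbon proves sensitive to the group it carries: naphthalen-1-yl gives a 6.7-fold lower number from compound 3 to compound 4 (0.82 log units; beyond the scatter), a 9.7-fold lower number from compound 2 to compound 4 (0.99 log units; beyond the scatter) and a 3.5-fold lower number from compound 1 to compound 4 (0.54 log units; beyond the scatter). Among the compounds shown here, all three steps lie beyond the scatter, so compound 4 is the least tolerated of the four, and it is the only one here whose group on this carbon has two six-membered aromatic rings of carbon only. No supporting measurement bears on why this change lowers the number.

Going by these compounds, it remains open whether the lower number goes with the second ring itself or with how the ring system is attached, which naphthalen-2-yl on the same carbonyl carbon could separate. Also open, on these data alone, is how a phenyl ring carrying an amine or a carboxylic acid would read at this place.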